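Diethylamino for Dimethylamino on a Second Core

This account rests on a few compounds, and the source may have more. Where it says the series, first, only, none or still open, it means among the compounds named here.

Three compounds have been measured in a functional assay on HeLa cells (Homo sapiens) for antiproliferative activity, read by MTT assay, with a stated time of 48 h; a higher number here means a weaker inhibitor, a lower number a stronger inhibitor:
Compound 1, `CN(C)CCCn1c(N)c(-c2nc3ccccc3[nH]2)c2nc(C#N)c(C#N)nc21`, gives 25900 nM.
Compound 2, `CCN(CC)CCCn1c(N)c(-c2nc3ccccc3[nH]2)c2nc(C#N)c(C#N)nc21`, gives 3150 nM.
Compound 3, `CN(C)CCCCn1c(N)c(-c2nc3ccccc3o2)c2nc(C#N)c(C#N)nc21`, gives 1950 nM.

Compound 1 and compound 2 share one core and differ in a single place: diethylamino in place of dimethylamino on a saturated chain carbon, three bonds along the chain from an aromatic nitrogen. That change produced an 8.2-fold lower number from compound 1 to compound 2 (0.91 log units; beyond the scatter). Compound 3 is built on a different core; the difference between its core and the core of compound 1 is not broken down here. Compound 3 has the lowest number of the three, but its gap to compound 2 lies within the scatter, so no order between those two is claimed; only against compound 1 does compound 3 stand clearly as the stronger inhibitor.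

Compound 4, `CCN(CC)CCCCn1c(N)c(-c2nc3ccccc3o2)c2nc(C#N)c(C#N)nc21`, has not yet been measured. It differs from compound 3 in one place: diethylamino in place of dimethylamino on a saturated chain carbon, four bonds along the chain from an aromatic nitrogen. Among the measured compounds shown here, this is the same kind of change as the one from compound 1 to compound 2, though not the same: there the amine sits three bonds along the chain from the aromatic nitrogen, here four bonds, and the core is the other one. The step is expected to run in the same direction and to be a 3.9-fold lower number from compound 3 to compound 4 (0.59 log units; beyond the scatter), resting on an 8.2-fold lower number from compound 1 to compound 2 (0.91 log units; beyond the scatter) but held somewhat smaller, since the change is seen only once and at a different place. Compound 4 is therefore expected to give about 500 nM, most likely between 150 nM and 1600 nM.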

Compound 4, half-maximal inhibitory concentration: 6420 nM
Beside the measured number, compound 4's estimate is 13-fold (1.11 log units) below it; measured number outside the range, above it.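

In this assay diethylamino in place of dimethylamino, on a saturated chain carbon four bonds along the chain from an aromatic nitrogen, gave a 3.3-fold higher number from compound 3 to compound 4 (0.52 log units; beyond the scatter) and so did not repeat the step seen on the core of compound 1. The change therefore does not carry over from one core to the other in this series with its direction kept, and the two steps differ by more than scatter: the same change on two cores in this assay, an 8.2-fold lower number (0.91 log units; beyond the scatter) from compound 1 to compound 2 and a 3.3-fold higher number (0.52 log units; beyond the scatter) from compound 3 to compound 4, 27-fold (1.43 log units) apart, beyond the scatter of two such steps

What this does not show is which difference reverses the step, for the two pairs differ both in the core and in how far along the chain the amine sits, and each pair has been seen only once. Nor does it show that either direction holds for this change more generally, since the series offers only these two pairs for comparison.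

Still open, on these data alone, is how the same change would run on the core of compound 1 with the amine four bonds along the chain, or on the core of compound 3 with it three bonds along, either of which would separate the two differences. Also open, as far as these compounds go, is what a cyclic amine such as pyrrolidine or morpholine, or a longer chain, would give on either core.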